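Aryloxy change on the shared core: compound 1 to compound 3

The compounds below may be only part of what the source reports. "The series", "measured", "known", "first", "only" and "open" are said of these compounds alone.

The series is read in a functional assay on NCI-H322M cells (Homo sapiens) for inhibition, read by sulforhodamine B assay, with a stated time of 48 h; on this read-out higher numbers stand for weaker inhibition of growth and lower numbers for stronger inhibition of growth. Going by the values given here, compound 1 `Nc1cc(N)c2nc(-c3ccccc3)c(Oc3ccc(Cl)c(Cl)c3)nc2c1` gives 21400 nM there and holds the lower of the two numbers measured so far. Among the compounds with values here, compound 2 `CCOC(=O)[C@H](CCC(=O)O)NC(=O)c1ccc(Oc2nc3cc(N)cc(N)c3nc2-c2ccccc2)cc1` gives 67600 nM in this assay, a higher number than compound 1 that lies beyond the scatter of repeat runs; the two compounds differ in more than one place, so no single step connects them.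

Compound 3 `Nc1cc(N)c2nc(-c3ccccc3)c(Oc3ccc(F)cc3)nc2c1` is the next entry for this assay. Its difference from compound 1 is 4-fluorophenyl in place of 3,4-dichlorophenyl on an oxygen on an aromatic ring, in words 4-fluorophenyl in place of 3,4-dichlorophenyl on an oxygen on an aromatic ring. Within the data shown here, no measured pair in the set shows this change, so its size is not known from the data. Given that compound 1 already sits at weak growth inhibition with 21400 nM, the expectation is a small step, most likely toward a somewhat higher number, possibly none beyond the scatter. The step is expected to read a 1.6-fold higher number from compound 1 to compound 3 (0.21 log units; within the scatter). Compound 3 is therefore estimated at 35000 nM in this assay, with a range from 12000 nM to 100000 nM.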

Compound 3, concentration for 50% growth inhibition: 17000 nM
Compound 3: middle estimate off by 2.1-fold (0.31 log units), on the high side, within the range that was stated.
By their numbers in this assay, from the lowest: compounds 3 and 1 (each within the scatter of the next); then compound 2.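

In this assay, going by these compounds alone, the first single-place reading at this oxygen-linked aryl group is a 1.3-fold lower number from compound 1 to compound 3 (0.10 log units; within the scatter), so 4-fluorophenyl in place of 3,4-dichlorophenyl leaves the read-out unchanged within the scatter. Compound 1 and compound 3 can therefore be treated as one level for this change, and neither aryl group can be ranked over the other; the two chlorine atoms are not required for the level of growth inhibition seen with compound 1, as fluorine alone at the 4-position of the phenyl ring gives a matching reading. No supporting data bear on the reason the two halogenated aryl groups read alike.

Going by these compounds, both aryl groups at this position carry halogen only, so it remains open whether a methoxy group, an amine or a carboxylic acid on the phenyl ring would shift the number beyond the scatter, or whether an unsubstituted phenyl would read the same. The link between compound 1 and the much larger substituent of compound 2 also stays unresolved, since intermediate groups such as a benzoic acid or a simple benzamide on the oxygen are not among the compounds shown.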